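Swapping Fluorines for Chlorine on a Benzyl Group

The source may report more compounds than this note shows. Statements on the series, on what has been measured and on what is new or still open speak of the compounds shown alone.

Among the measured compounds shown here, compound 2 `COc1ccc(N2C(=O)N(Cc3c(F)cc(F)cc3F)c3ccccc3S2(=O)=O)cc1OC` is one of two compounds measured in an assay on HEK293 cells for displacement of a labelled ligand from Orexin receptor type 2 (Homo sapiens), read by scintillation counting, with a stated time of 90 min; a lower number here means a stronger inhibitor, a higher number a weaker inhibitor. In this assay compound 2 gives 2 nM, the higher of the two numbers, while compound 1 `COc1cc(F)c(CN2C(=O)N(c3cc(OC)nc(OC)c3)S(=O)(=O)c3ccccc32)c(F)c1` gives 0.251 nM in this assay, a gap that lies beyond the scatter. Compound 3 `COc1ccc(N2C(=O)N(Cc3ccc(F)cc3Cl)c3ccccc3S2(=O)=O)cc1OC` has not yet been measured. It differs from compound 2 in a single place: 2-chloro-4-fluorophenyl in place of 2,4,6-trifluorophenyl on a saturated chain carbon bound to an amide-type nitrogen in a ring. For the measured compounds named here, no measured pair shows this particular change, so its effect cannot be read off directly. The change replaces one halogen-bearing ring with another of the same shape, and everything else in compound 2 is kept. Only a modest step is expected, a 1.3-fold lower number from compound 2 to compound 3 (0.12 log units; within the scatter), probably not clearly beyond the scatter. Compound 3 is therefore expected to give about 1.5 nM in this assay, with a likely range from 0.5 nM to 5 nM.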

Compound 3, inhibition constant: 25.1 nM
The estimate for compound 3 lay 17-fold (1.22 log units) below the measured number; measured number above the stated range.
By their numbers in this assay, from the lowest: compound 1; then compound 2; then compound 3.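

In this assay, among the compounds shown here, this change gives a 13-fold higher number from compound 2 to compound 3 (1.10 log units; beyond the scatter) and so provides the first direct reading at this position. It shows that the halogens on this benzyl group are not interchangeable, even though the ring stays a six-membered aromatic ring of carbon only, with no hydrogen-bond donors or acceptors on either side. No supporting measurement explains the loss.

The change removes two fluorines and adds one chlorine in a single step, so the compounds shown cannot separate the effect of losing fluorine from that of gaining chlorine. They also leave open how this position would respond to a benzyl group with no halogen at all, or to one carrying a nitrile or a trifluoromethyl group.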